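Moving the methoxy on the piperidine amide

This account rests on a few compounds, and the source may have more. Where it says the series, first, only, none or still open, it means among the compounds named here.

Compound 3 `COC1CCN(C(=O)N2CC(c3nc(-c4cccc(Cl)c4)no3)C2)CC1` carries a 4-methoxypiperidin-1-yl group on the carbonyl carbon of the shared core. In an assay on HEK293 cells for negative allosteric modulation of metabotropic glutamate receptor 5 (Homo sapiens), read by FLIPR (a lower number here means a stronger inhibitor, a higher number a weaker inhibitor), compound 3 gives > 10000 nM, which is a limit of the assay and not a number. Compound 1 `CC1CCC(C(=O)N2CC(c3nc(-c4cccc(Cl)c4)no3)C2)CC1` gives > 10000 nM, again a limit. Compound 2 `O=C(N1CCCCCC1)N1CC(c2nc(-c3cccc(Cl)c3)no2)C1` gives > 10000 nM, also a limit. Within the data shown here, the steps a step that the two limits leave unreadable from compound 1 to compound 2, a step that the two limits leave unreadable from compound 1 to compound 3 and a step that the two limits leave unreadable from compound 2 to compound 3 are therefore unreadable, and the only evidence available is the limit of > 10000 nM in this assay, at which 3 of the 3 values shown sit.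

Compound 4 `COC1CCCN(C(=O)N2CC(c3nc(-c4cccc(Cl)c4)no3)C2)C1` differs from compound 3 in one place: 3-methoxypiperidin-1-yl in place of 4-methoxypiperidin-1-yl on a carbonyl carbon. Among the measured compounds shown here, no measured step bears on this change in a readable way, since the three measured compounds all sit at the limit. With the amide substituent varied across a cyclohexyl, an azepanyl and a methoxypiperidinyl group without any value emerging below the limit, compound 4 is expected to behave alike, and the estimated step is a step that the limit leaves unreadable from compound 3 to compound 4. Compound 4 is expected to give about 15000 nM in this assay, between 3000 nM and 60000 nM, most likely reported only as a limit.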

Compound 4, half-maximal inhibitory concentration: 1830 nM
The estimate for compound 4 lay 8.2-fold (0.91 log units) above the measured number; measured number below the stated range.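

In this assay the change to 3-methoxypiperidin-1-yl brings an at least 5.4-fold lower number from compound 3 to compound 4 (0.73 log units; beyond the scatter) even though the two groups have the same atoms, so the place of the methoxy on the piperidine matters here. The same group also gives an at least 5.4-fold lower number from compound 2 to compound 4 (0.73 log units; beyond the scatter) and an at least 5.4-fold lower number from compound 1 to compound 4 (0.73 log units; beyond the scatter) when it replaces azepan-1-yl and 4-methylcyclohexyl on the carbonyl carbon. These three steps give only minimum sizes and the steps among compounds 1, 2 and 3 cannot be read, because those compounds give only a limit: the limit of > 10000 nM in this assay, at which 3 of the 4 values shown sit.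

Going by these compounds, whether the methoxy itself is needed stays open, and 3-hydroxypiperidin-1-yl, 3-ethoxypiperidin-1-yl or plain piperidin-1-yl on the same carbonyl carbon would test this. Also open, on these data alone, is whether the value of compound 4 rests mainly on one mirror-image form of its 3-methoxypiperidin-1-yl group.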